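The source may hold more compounds than are shown below. What is called first, only, known or untested is meant among the compounds shown, and "the series" means these compounds.

Going by the values given here, compound 3 `COc1cc(Cl)cc(-c2nn(-c3cccc(NC(=O)Nc4cc(C(F)(F)F)cc(C(F)(F)F)c4)c3)cc2-c2ccncc2)c1` gives 360 nM in a functional assay on UACC-62 cells (Homo sapiens) for inhibition, read by sulforhodamine B assay, with a stated time of 48 h (a higher number here means a weaker inhibitor, a lower number a stronger inhibitor), the lowest number of the three measured so far; the gaps to compound 2 `O=C(Nc1cccc(-n2cc(-c3ccncc3)c(-c3cc(O)cc(Cl)c3)n2)c1)Nc1ccc(Cl)c(Cl)c1` with 1690 nM and to compound 1 `O=C(Nc1cccc(-n2cc(-c3ccncc3)c(-c3cc(O)cc(Cl)c3)n2)c1)Nc1ccc(Cl)c(C(F)(F)F)c1` with 2080 nM both lie beyond the scatter, though each of those two differs from compound 3 in more than one place. Compound 4 `COc1cc(Cl)cc(-c2nn(-c3cccc(NC(=O)Nc4cccc(C(F)(F)F)c4)c3)cc2-c2ccncc2)c1` differs from compound 3 by hydrogen in place of trifluoromethyl on an aromatic carbon. Among the compounds with values here, the only measured step on that end of the urea is a 1.2-fold lower number from compound 1 to compound 2 (0.09 log units; within the scatter), a swap of one group for another rather than a removal. Within the data shown here, no measured pair shows a trifluoromethyl taken away outright. For compound 4 a modest rise in the number is expected, a 1.8-fold higher number from compound 3 to compound 4 (0.26 log units; within the scatter), with a wide range. Compound 4 is estimated at 650 nM, between 250 nM and 1700 nM.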

Compound 4, half-maximal inhibitory concentration: 1470 nM
Compound 4: middle estimate off by 2.3-fold (0.35 log units), on the low side; the measured number falls inside the stated range.
By their numbers in this assay, from the lowest: compound 3; then compounds 4, 2 and 1 (each within the scatter of the next).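

In this assay, taking a trifluoromethyl away outright, with the other trifluoromethyl kept, gives a change beyond the scatter: a 4.1-fold higher number from compound 3 to compound 4 (0.61 log units; beyond the scatter). Going by these compounds alone, the only earlier step on this end of the urea, a 1.2-fold lower number from compound 1 to compound 2 (0.09 log units; within the scatter), was a swap of one group for another and stayed within the scatter, so this aromatic carbon is the first place on that end where a change registers. Nothing available accounts for the loss.

As far as these compounds go, whether a methyl or an amine on this carbon would restore the number of compound 3 remains open. Also open, from the compounds shown here alone, is whether the same removal costs as much with the hydroxy group of compound 1 and compound 2 in place of the methoxy.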